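This account rests on a few compounds, and the source may have more. Where it says the series, first, only, none or still open, it means among the compounds named here.

Measured compounds:
compound 1, `CCCn1c(=O)[nH]c2nc(-c3ccc(S(=O)(=O)N4CCN(c5ccc(F)cc5)CC4)cc3)[nH]c2c1=O`: 14%
compound 2, `CCCn1c(=O)[nH]c2nc(-c3ccc(S(=O)(=O)N4CCN(c5cccc(Cl)c5)CC4)cc3)[nH]c2c1=O`: 21%
compound 3, `CCCn1c(=O)[nH]c2nc(-c3ccc(S(=O)(=O)N4CCN(c5ccccc5Br)CC4)cc3)[nH]c2c1=O`: 28%

All three were tested in an assay on CHO cells for displacement of a labelled ligand from adenosine receptor A1 (Homo sapiens), read by scintillation counting, with a stated time of 90 min, tested at 1 uM, in the presence of a further agent that is not named here; a lower number here means less inhibition, a higher number more inhibition at the concentration tested (going by the name of the read-out). Compound 2, with 21%, has the second highest number of the three, but its neighbours sit close: the step of a number 7 percentage points higher from compound 1 to compound 2 (within the scatter) and the step of a number 7 percentage points higher from compound 2 to compound 3 (within the scatter) are both within the scatter, so compound 2 cannot be ordered against either.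

Compound 4, `CCCn1c(=O)[nH]c2nc(-c3ccc(S(=O)(=O)N4CCN(c5ccccc5F)CC4)cc3)[nH]c2c1=O`, differs from compound 2 by 2-fluorophenyl in place of 3-chlorophenyl on an amine nitrogen in a ring. Within the data shown here, two measured steps bear on this change. Compound 3 also carries a 2-halophenyl, and the step of a number 14 percentage points higher from compound 1 to compound 3 (beyond the scatter) was beyond the scatter, while the step of a number 7 percentage points higher from compound 2 to compound 3 (within the scatter) was not. Compound 1 carries a fluorine, though as 4-fluorophenyl, and gives 14%. Taken together, a small rise at most is expected, a number 3 percentage points higher from compound 2 to compound 4 (within the scatter), likely within the scatter. Compound 4 is therefore estimated at 24%, in the range 12% to 36%.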

Compound 4, a percentage reported as inhibition, at one concentration (the size of the read-out at that concentration, not a potency): 13%
Compound 4: middle estimate off by 11 percentage points, on the high side, within the range that was stated.
By their numbers in this assay, from the lowest: compounds 4, 1, 2 and 3 (each within the scatter of the next, the first and the last beyond it).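

In this assay, among these compounds, the one step beyond the scatter is fluoro in place of bromo on an aromatic carbon, a number 15 percentage points lower from compound 3 to compound 4 (beyond the scatter) (the first sign that the kind of halogen on this phenyl group can count while the rest of the molecule stays the same). The two other changes at this place give a number 1 percentage points lower from compound 1 to compound 4 (within the scatter) and a number 8 percentage points lower from compound 2 to compound 4 (within the scatter) and so cannot be told apart from repeat-to-repeat variation. Compound 4 also carries a 2-halophenyl group, so having a halogen at that ring position does not on its own go with the higher number of compound 3.

As far as these compounds go, whether 2-chlorophenyl, 2-methoxyphenyl or plain phenyl on the same ring nitrogen would read like compound 3 or like compound 4 stays open. No measurement shown explains the difference between fluoro and bromo here.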